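Swapping trifluoromethyl for an oxazole on the shared core

The compounds below may be only part of what the source reports. "The series", "measured", "known", "first", "only" and "open" are said of these compounds alone.

Compound 1 `Cc1ccc(Cn2c(=O)[nH]c3c(N)nc(C(F)(F)F)cc32)cn1`: 0.767 h in an ADME assay on cytosol (Rattus norvegicus) for metabolic stability; on this read-out higher numbers stand for a longer-lived compound and lower numbers for a shorter-lived compound
Compound 2 `Cc1nc(Cn2c(=O)[nH]c3c(N)nc(C(F)(F)F)cc32)co1`: > 16.6 h in this assay, which is a limit of the assay and not a number

In this assay, within the data shown here, compound 1 gives the only number among the values shown; the other value is a limit. That limit belongs to compound 2 and is described by the limit of > 16.6 h in this assay, at which 1 of the 2 values shown sits. Among the measured compounds shown here, the one measured step, an at least 21-fold higher number from compound 1 to compound 2 (1.33 log units; beyond the scatter), concerns the group on the saturated chain carbon bound to the aromatic nitrogen and is large. Compound 3 `Cc1ccc(Cn2c(=O)[nH]c3c(N)nc(-c4ncco4)cc32)cn1` changes a different place: 1,3-oxazol-2-yl in place of trifluoromethyl on an aromatic carbon. For the measured compounds named here, no measured step touches this position, so the measured step gives no direct guidance on it, and the expectation rests on the number for compound 1 alone. With nothing pointing either way, a step of no size beyond the scatter is expected, written as a 1.0-fold higher number from compound 1 to compound 3 (0.02 log units; within the scatter). Compound 3 is therefore estimated at 0.8 h, with a range from 0.25 h to 3 h.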

Compound 3, half-life: 0.767 h
Compound 3: the middle estimate sits 1.0-fold (0.02 log units) above what was measured; the measured number falls inside the stated range.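

Putting 1,3-oxazol-2-yl in place of trifluoromethyl on the aromatic carbon gave no change at the digits printed from compound 1 to compound 3 (within the scatter) in this assay. Among these compounds, this is the first reading at this position, and it shows that a five-membered aromatic ring can stand here with the half-life of compound 1 unmoved, whereas the change on the saturated chain carbon gave an at least 21-fold higher number from compound 1 to compound 2 (1.33 log units; beyond the scatter) in the same read-out. Nothing shown bears on why trifluoromethyl and 1,3-oxazol-2-yl read alike here.

The compounds shown leave open whether other groups on this carbon, such as a nitrile, an amine or a carboxylic acid, would read the same. They also leave open whether 1,3-oxazol-2-yl here would behave alike with the 2-methyl-1,3-oxazol-4-yl group of compound 2, whose value is a limit of the assay and not a number.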